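This account rests on a few compounds, and the source may have more. Where it says the series, first, only, none or still open, it means among the compounds named here.

Working notes on the series. Compound 1 (`Oc1ccc(-c2cc(-c3ccccc3)cc(-c3ccccc3)n2)cc1`) carries phenyl where compound 2 (`Oc1ccc(-c2cc(-c3ccccc3)cc(-c3ccco3)n2)cc1`) carries furan-2-yl. In a functional assay on HL-60 cells (Homo sapiens) for cytotoxicity, read by ELISA, with a stated time of 2 days (a higher number here means a weaker inhibitor, a lower number a stronger inhibitor), compound 1 gives 1400 nM and compound 2 gives 3300 nM, so compound 2 holds the higher, weaker number of the two. Compound 3 (`Oc1ccc(-c2cc(-c3ccccc3)cc(-c3ccc(O)cc3)n2)cc1`) has 4-hydroxyphenyl in place of furan-2-yl on an aromatic carbon, next to the ring nitrogen: 4-hydroxyphenyl in place of furan-2-yl on an aromatic carbon. Among the measured compounds shown here, the only measured step bearing on this change is a 2.4-fold higher number from compound 1 to compound 2 (0.37 log units; beyond the scatter), which is modest and beyond the scatter. It swaps phenyl for furan-2-yl at the same place. For the measured compounds named here, no measured compound carries 4-hydroxyphenyl there, so the reversal of that step is only a guide. A modest move to a lower number in this assay is expected, and the expected change is a 1.8-fold lower number from compound 2 to compound 3 (0.26 log units; within the scatter). The estimate for compound 3 is 1800 nM, with an expected range of 600 nM to 5000 nM.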

Compound 3, half-maximal inhibitory concentration: 5700 nM
Beside the measured number, compound 3's estimate is 3.2-fold (0.50 log units) below it; the measured number lies above the stated range.
By their numbers in this assay, from the lowest: compound 1; then compounds 2 and 3 (each within the scatter of the next).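

At this position, on an aromatic carbon next to the ring nitrogen, this assay does not separate 4-hydroxyphenyl from furan-2-yl, with a 1.7-fold higher number from compound 2 to compound 3 (0.24 log units; within the scatter) for that exchange. The clearer new reading comes from the hydroxy group on the phenyl at this place: hydroxy in place of hydrogen gives a 4.1-fold higher number from compound 1 to compound 3 (0.61 log units; beyond the scatter) and is a second change away from phenyl, alongside furan-2-yl, that ends at a weaker number than compound 1 shows. No evidence is available on what lies behind these differences.

Open, as far as these compounds go, is whether a methoxy group, an amine or a carboxylic acid in place of that hydroxy would read like compound 3 or like compound 1. Also open is how a short alkyl chain on this carbon would compare with the aromatic rings shown here.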